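Thiomorpholine for morpholine on a thiosemicarbazide thiocarbonyl

The source may report more compounds than this note shows. Statements on the series, on what has been measured and on what is new or still open speak of the compounds shown alone.

Of the compounds shown here, two have so far been measured in a functional assay on A-431 cells (Homo sapiens) for cytotoxicity, read by MTT assay, with a stated time of 72 h, tested at 30 uM; a higher number here means more inhibition of growth at the concentration tested, a lower number less inhibition of growth. Compound 1 `N/C(=N\NC(=S)N1CCOCC1)c1ccccn1` gives 78.8% in this assay, and compound 2 `Cc1ccnc(/C(N)=N/NC(=S)N2CCOCC2)c1` gives 74.6%. Going by the values given here, the only step between them, a number 4.2 percentage points lower from compound 1 to compound 2 (within the scatter), leaves the two compounds indistinguishable on this read-out, so compound 2 stands alongside compound 1 rather than apart from it.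

Compound 3 `Cc1ccnc(/C(N)=N/NC(=S)N2CCSCC2)c1` has not yet been measured. It differs from compound 2 in one place: thiomorpholin-4-yl in place of morpholin-4-yl on a thiocarbonyl carbon. Among the compounds with values here, no measured step touches that part of the molecule; the one step that exists, from compound 1 to compound 2, concerns the aromatic ring and says nothing about the ring on the thiocarbonyl carbon. Within the data shown here, what can be said is that the shared core has held its inhibition through the only change tried so far. On that basis compound 3 is expected to stay close to compound 2, with an expected step of a number 1.6 percentage points lower from compound 2 to compound 3 (within the scatter) that need not exceed the scatter. The estimate for compound 3 in this assay is therefore 73%, within a range from 58% to 86%.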

Compound 3, percent growth inhibition at one concentration: 75.3%
Compound 3: the middle estimate sits 2.3 percentage points below what was measured; low and high end bracket the measured number.
By their numbers in this assay, from the lowest: compounds 2, 3 and 1 (each within the scatter of the next).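

Going by these compounds alone, compound 3 gives the first measurement of a change on the thiocarbonyl carbon: in this assay, thiomorpholin-4-yl in place of morpholin-4-yl gives a number 0.7 percentage points higher from compound 2 to compound 3 (within the scatter). Within the data shown here, this place therefore tolerates the exchange of the ring oxygen for sulfur without any change that this read-out can resolve, whereas the earlier compounds spoke only to the methyl on the aromatic carbon. The two groups match in heavy-atom count, ring size, donors, acceptors and charge, so the exchange tests only this one atom, and the result does not show how far this place would tolerate a group that departs further from morpholin-4-yl. Nothing available explains why the two rings read alike.

The compounds shown leave open whether a ring carrying a second nitrogen, such as piperazin-1-yl, or an open-chain group such as dimethylamino, would hold the same growth inhibition on the thiocarbonyl carbon. They also leave open whether thiomorpholin-4-yl would read the same on the core of compound 1, which lacks the methyl.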